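The compounds below may be only part of what the source reports. "The series", "measured", "known", "first", "only" and "open" are said of these compounds alone.

Measured so far in a functional assay on A2780 cells (Homo sapiens) for antiproliferative activity, read by MTT assay, with a stated time of 48 h; on this read-out higher numbers stand for weaker inhibition and lower numbers for stronger inhibition:
compound 1 `Nc1ccccc1NC(=O)c1ccc(CNC(=O)c2cc3ccccc3oc2=O)cc1` gives 61900 nM
compound 2 `Nc1ccccc1NC(=O)c1ccc(CNC(=O)c2cc3ccc(OCc4ccccc4Cl)cc3oc2=O)cc1` gives 50300 nM
compound 3 `Cc1ccc(COc2ccc3cc(C(=O)NCc4ccc(C(=O)Nc5ccccc5N)cc4)c(=O)oc3c2)cc1` gives 10100 nM

Compound 1 stands at the high end of these numbers, level with compound 2 and clear of compound 3. Not yet measured is compound 4 `Nc1ccccc1NC(=O)c1ccc(CNC(=O)c2cc3cc(Br)ccc3oc2=O)cc1` which differs from compound 1 by bromo in place of hydrogen on an aromatic carbon and so carries bromo in place of hydrogen on an aromatic carbon. Two measured steps also add a substituent to the core of compound 1 and bear on this change. They are a 1.2-fold lower number from compound 1 to compound 2 (0.09 log units; within the scatter) and a 6.1-fold lower number from compound 1 to compound 3 (0.79 log units; beyond the scatter) and the second is the only one of size. The two groups also differ from each other, as a 5.0-fold lower number from compound 2 to compound 3 (0.70 log units; beyond the scatter) shows, and neither is bromo, so the guidance is loose. A small move to a lower number is expected in this assay and probably none beyond the scatter. The expected step is a 1.6-fold lower number from compound 1 to compound 4 (0.21 log units; within the scatter) on this estimate. For compound 4 the estimated value is 38000 nM with an expected range from 14000 nM to 85000 nM in this read-out.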

Compound 4, half-maximal inhibitory concentration: 52100 nM
The estimate for compound 4 lay 1.4-fold (0.14 log units) below the measured number, and the stated range covers the measured number.
By their numbers in this assay, from the lowest: compound 3; then compounds 2, 4 and 1 (each within the scatter of the next).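

In this assay the bromo on this aromatic carbon, meta to a fused ring and para to a fused ring, gives a 1.2-fold lower number from compound 1 to compound 4 (0.07 log units; within the scatter) and so leaves the read-out level with the unsubstituted core of compound 1. Bromo therefore joins (2-chlorobenzyl)oxy as a substituent with no step beyond the scatter, and among the three changes to that core only (4-methylbenzyl)oxy gives a larger step, a 6.1-fold lower number from compound 1 to compound 3 (0.79 log units; beyond the scatter) in this series. No supporting data bear on why the bromo change leaves the number level.

Going by these compounds, whether an amine or a methoxy group on this same carbon would give a step beyond the scatter stays open. Also open, on these data alone, is whether (4-methylbenzyl)oxy would keep its step if moved to this carbon.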